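Moving the Acid and Swapping Hydroxyl for Chlorine

The source may hold more compounds than are shown below. What is called first, only, known or untested is meant among the compounds shown, and "the series" means these compounds.

Compound 1 `O=C(O)c1cc(-c2cccc(COc3ccc4c(c3)CN(C3CCCC3)C4=O)c2)ccc1O`: 20 nM
Compound 2 `O=C(O)c1cc(-c2cccc(COc3ccc4c(=O)n(C5CC5)sc4c3)c2)ccc1Cl`: 130 nM
Compound 3 `O=C(O)c1cc(-c2cccc(COc3ccc4c(=O)n(CC5CC5)sc4c3)c2)ccc1Cl`: 2480 nM

In an assay on HEK293 cells for positive allosteric modulation of metabotropic glutamate receptor 2 (Rattus norvegicus), read by thallium flux (on this read-out lower numbers stand for an effect already at smaller amounts and higher numbers for an effect only at larger amounts of compound), compound 1 gives the lowest of the three numbers, while compound 2 gives 130 nM and compound 3 gives 2480 nM. For the measured compounds named here, the only measured step, a 19-fold higher number from compound 2 to compound 3 (1.28 log units; beyond the scatter), concerns the group on the aromatic nitrogen at the far end of the shared core and says nothing about the acid-bearing ring. Compound 4 `O=C(O)c1ccc(Cl)c(-c2cccc(COc3ccc4c(c3)CN(C3CCCC3)C4=O)c2)c1` differs from compound 1 in exactly that ring: 5-carboxy-2-chlorophenyl in place of 3-carboxy-4-hydroxyphenyl on an aromatic carbon. Going by the values given here, no measured step bears on this change, and both the carboxylic acid and the neighbouring substituent are altered at once, so a weaker effect is expected, a 10-fold higher number from compound 1 to compound 4 (1.00 log units; beyond the scatter). Compound 4 is therefore estimated at about 200 nM, in a range from 40 nM to 1500 nM.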

Compound 4, half-maximal effective concentration: 90 nM
Estimate against measurement, compound 4: 2.2-fold (0.35 log units) above, and the stated range covers the measured number.
By their numbers in this assay, from the lowest: compound 1; then compounds 4 and 2 (each within the scatter of the next); then compound 3.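

Putting 5-carboxy-2-chlorophenyl in place of 3-carboxy-4-hydroxyphenyl in this assay gives a 4.5-fold higher number from compound 1 to compound 4 (0.65 log units; beyond the scatter) and so shows that this ring affects the number, yet a clear effect remains after the change. The place of the acid and the swap of hydroxyl for chlorine change together, so the step cannot be divided between them. Nothing at hand explains the size of this step. Left open is how the core of compound 1 responds to either change alone, and whether a tetrazole or an amine can stand in place of the carboxylic acid.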